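Swapping the amide aryl group and cell tolerance

The source may report more compounds than this note shows. Statements on the series, on what has been measured and on what is new or still open speak of the compounds shown alone.

Compound 1, `CC(C)n1ncc2c(C(=O)Nc3cccc(C(N)=O)c3)cc(-c3cccs3)nc21`, in an ADME assay on LLC-MK2 cells (Macaca mulatta) for cytotoxicity, read by spectrophotometry and crystal violet staining, with a stated time of 4 days; a lower number here means that less compound is tolerated, a higher number that more compound is tolerated: 25000 nM
Compound 2, `CC(C)n1ncc2c(C(=O)Nc3ccc(F)cc3)cc(-c3ccsc3)nc21`: > 200000 nM, which is a limit of the assay and not a number
Compound 3, `CC(C)n1ncc2c(C(=O)Nc3ccc(F)cc3)cc(-c3ccco3)nc21`: > 200000 nM, which is a limit of the assay and not a number

Among these three, compound 1 is the only one for which this assay returned a number at all. The other two reached only (the limit of > 200000 nM in this assay, at which 2 of the 3 values shown sit), so compound 1 stands alone as the compound that the cells tolerated least well.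

Compound 4, `CC(C)n1ncc2c(C(=O)Nc3cccnc3)cc(-c3cccs3)nc21`, has not yet been measured. It differs from compound 1 in one place: pyridin-3-yl in place of 3-carbamoylphenyl on an amide-type nitrogen. Within the data shown here, only one step between measured compounds exists, a step that the two limits leave unreadable from compound 2 to compound 3, and both of its ends are limits, leaving its size unreadable; it also concerns a different place on the shared core, an aromatic carbon rather than the amide-type nitrogen. Among the measured compounds shown here, no measured step therefore bears on the change from compound 1 to compound 4, and compound 1's own value is the only anchor.

Compound 4 is expected to give about 40000 nM, between 10000 nM and 200000 nM. The step this estimate implies, a 1.6-fold higher number from compound 1 to compound 4 (0.20 log units; within the scatter), is expected to stay within the usual scatter, with a real chance that only a limit is reported.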

Compound 4, half-maximal cytotoxic concentration: > 200000 nM
Compound 4: no number, only a limit (the forecaster's own chance of this, stated with the estimate: 35%); middle value at least 5.0-fold (0.69 log units) away from the limit.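

Placing pyridin-3-yl instead of 3-carbamoylphenyl on the amide-type nitrogen gives, in this assay, an at least 8.0-fold higher number from compound 1 to compound 4 (0.90 log units; beyond the scatter), so a change at this position can shift cell tolerance by more than the usual scatter. Among these compounds, the earlier compounds could not show this, as their only step concerned an aromatic carbon and had a limit at both ends. The size printed for the new step is only a minimum, because compound 4 also gave a limit rather than a number, and compound 1 remains the only compound with a measured value: the limit of > 200000 nM in this assay, at which 3 of the 4 values shown sit.

The change replaces the whole group, so the compounds shown cannot separate the loss of the carbamoyl group from the exchange of a ring carbon for a ring nitrogen. They also leave open how the cells would tolerate plain phenyl on the amide-type nitrogen, or a phenyl ring carrying a carboxylic acid or an amine there, and whether any such group would give a number rather than a limit in this assay.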